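This account rests on a few compounds, and the source may have more. Where it says the series, first, only, none or still open, it means among the compounds named here.

Measured compounds:
compound 1, `COc1ccc(/C=C/S(=O)(=O)Cc2ccc(OC)c([N+](=O)[O-])c2)cc1`: 25000 nM
compound 2, `COc1ccc(/C=C/S(=O)(=O)Cc2ccc(OC)c(N)c2)cc1`: 2500 nM
compound 3, `COc1cc(OC)c(/C=C/S(=O)(=O)Cc2ccc(OC)cc2[N+](=O)[O-])c(OC)c1`: 20000 nM

In a functional assay on DU-145 cells (Homo sapiens) for cytotoxicity, read by trypan blue exclusion, with a stated time of 96 h (on this read-out lower numbers stand for stronger inhibition and higher numbers for weaker inhibition), compound 1 gives 25000 nM. Among the measured compounds shown here, the single change amino in place of nitro on an aromatic carbon leads to compound 2, which gives 2500 nM, and the step of a 10-fold lower number from compound 1 to compound 2 (1.00 log units; beyond the scatter). Compound 3 gives 20000 nM in this assay; this number and that of compound 1 lie within the scatter of each other. The difference between the core of compound 3 and the core of compound 1 is not broken down here.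

Compound 4, `COc1ccc(CS(=O)(=O)/C=C/c2c(OC)cc(OC)cc2OC)c(N)c1`, has not yet been measured in this assay. It differs from compound 3 by amino in place of nitro on an aromatic carbon. This is the same kind of change as that from compound 1 to compound 2, but the surroundings differ: in compound 2 the amino sits ortho to a methoxy group and meta to a large group, whereas in compound 4 it sits ortho to a large group and meta to a methoxy group. The step of an 8.0-fold lower number from compound 3 to compound 4 (0.90 log units; beyond the scatter) is expected, resting on the step of a 10-fold lower number from compound 1 to compound 2 (1.00 log units; beyond the scatter). Compound 4 is therefore estimated to give 2500 nM, between 800 nM and 8000 nM.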

Compound 4, half-maximal inhibitory concentration: 25 nM
The estimate for compound 4 lay 100-fold (2.00 log units) above the measured number; the measured number lies below the stated range.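

In this assay, amino in place of nitro on an aromatic carbon, here ortho to a large group and meta to a methoxy group, gave an 800-fold lower number from compound 3 to compound 4 (2.90 log units; beyond the scatter). The number fell on both cores, so the direction of the change carried over, but its size did not: the same change on two cores in this assay, a 10-fold lower number (1.00 log units; beyond the scatter) from compound 1 to compound 2 and an 800-fold lower number (2.90 log units; beyond the scatter) from compound 3 to compound 4, 80-fold (1.90 log units) apart, beyond the scatter of two such steps With only these two pairs, the result does not show whether the place of the amino group or the rest of the core accounts for the gap, and it gives no way to predict the size of the step on a further core.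

The compounds shown leave open whether a free amino group is needed at this place, or whether a hydroxyl, an acetamide or a dimethylamino group there would give a number close to that of compound 4. They also leave open what each of the two differences between the cores contributes, as the place of the amino group and the methoxy pattern vary together.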